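Hydroxy in place of methoxy on a shared core

The source may hold more compounds than are shown below. What is called first, only, known or untested is meant among the compounds shown, and "the series" means these compounds.

Compound 1 `Cc1cc(O)cc(-c2nn(CC#N)cc2-c2ccnc(-c3ccc(Oc4ccccc4)cc3)c2)c1` and compound 2 `COc1cc(C)cc(-c2nn(CC#N)cc2-c2ccnc(-c3ccc(N(C)C)cc3)c2)c1` share a core and differ at two places at once, so no single step can be read between them. In a functional assay on Hs-578T cells (Homo sapiens) for cytotoxicity, read by sulforhodamine B assay, with a stated time of 48 h, tested at 0.001 uM (a lower number here means a stronger effect, a higher number a weaker effect of the compound at the concentration tested), compound 1 gives 103%. In this assay compound 2 gives 103%, level with compound 1 at the digits shown, which puts the pair within the scatter of each other; neither number points to any effect at this concentration.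

Compound 3 `Cc1cc(O)cc(-c2nn(CC#N)cc2-c2ccnc(-c3ccc(N(C)C)cc3)c2)c1` is built from compound 2 by one change: hydrogen in place of methyl on an oxygen on an aromatic ring. The same kind of group, a hydroxy on that aromatic ring, stands in compound 1, and compound 1 and compound 2 sit at the same level in this assay, so nothing in the data suggests that this exchange moves the read-out. The step from compound 2 to compound 3 in this assay is expected to be none beyond the scatter, a number 1 percentage points lower from compound 2 to compound 3 (within the scatter). Compound 3 is therefore expected to give about 102% in this assay, in a range from 92% to 112%.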

Compound 3, a percentage reported as activity, at one concentration (the size of the read-out at that concentration, not a potency): 98%
Beside the measured number, compound 3's estimate is 4 percentage points above it; measured number inside the range.
By their numbers in this assay, from the lowest: compounds 3, 1 and 2 (each within the scatter of the next).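

Among these compounds, compound 3 gives the first clean reading of this position. Among the compounds shown here, only one thing changes on the 3-methoxy-5-methylphenyl group: methoxy becomes hydroxy. In this assay that exchange gives a number 5 percentage points lower from compound 2 to compound 3 (within the scatter) and so stays within the scatter, while the second single change, dimethylamino in place of phenoxy on an aromatic carbon with the hydroxy kept, gives a number 5 percentage points lower from compound 1 to compound 3 (within the scatter) and also stays within the scatter. Taken one at a time, neither change shifts the read-out by more than the usual variation between repeats, which the earlier pair could not show since it differed at two places at once, and no measurement at hand offers an explanation for these numbers.

As far as these compounds go, all of this rests on a single low concentration, so whether these groups would separate at higher concentrations, where the compounds might show a real effect on the cells, remains open. The compounds shown also leave open what a longer chain such as ethoxy on that oxygen, or a carboxylic acid or a primary amine in place of dimethylamino, would do.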